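Phenyl in place of acetyl: an expected shift in cytotoxicity

A few compounds are considered here, and "the series" means these few. Any claim that something is new, unique, unknown or untested is made for them only; others in the source may bear on it.

Compound 1 `O=C(CCCCC1CCSS1)NCc1cn(CCCOc2ccc3cc(-c4ccc(Cl)c(Cl)c4)c(=O)oc3c2)nn1` gives 42.4%.
Compound 2 `CC(=O)c1cc2ccc(OCCCCCn3cc(CNC(=O)CCCCC4CCSS4)nn3)cc2oc1=O` gives 27.4%.

In a functional assay on PC-12 cells (Rattus norvegicus) for cytotoxicity, read by MTT assay, with stated times of 3 h and 2 h, tested at 1 uM (on this read-out lower numbers stand for a weaker effect and higher numbers for a stronger effect at the one concentration tested), compound 2 stands lowest of the two numbers; the nearest number, that of compound 1, lies higher by more than the usual scatter. Compound 3 `O=C(CCCCC1CCSS1)NCc1cn(CCCCCOc2ccc3cc(-c4ccccc4)c(=O)oc3c2)nn1` differs from compound 2 in one place: phenyl in place of acetyl on an aromatic carbon. Within the data shown here, no step between measured compounds is known. Among the measured compounds shown here, a modest rise is expected, since the only other measured compound, compound 1, sits higher with 42.4%. The expected step of a number 7.6 percentage points higher from compound 2 to compound 3 (within the scatter) is upward, close to the edge of the scatter. Compound 3 is estimated at 35%, within 20% to 50%.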

Compound 3, a percentage reported as activity, at one concentration (the size of the read-out at that concentration, not a potency): 30.7%
Beside the measured number, compound 3's estimate is 4.3 percentage points above it; low and high end bracket the measured number.
By their numbers in this assay, from the lowest: compounds 2 and 3 (each within the scatter of the next); then compound 1.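

In this assay, phenyl in place of acetyl on this aromatic carbon gives a number 3.3 percentage points higher from compound 2 to compound 3 (within the scatter). At this position, then, a group of 3 heavy atoms with 1 hydrogen-bond acceptor and a six-membered aromatic ring with none cannot be told apart on this read-out. No available evidence bears on why this is so.

On these data alone, whether an amine or a carboxylic acid on this carbon would read differently remains open. So does the effect of a longer chain at this position.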